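Working notes: from compound 2 to compound 3

The compounds below may be only part of what the source reports. "The series", "measured", "known", "first", "only" and "open" are said of these compounds alone.

Two compounds of the series have numbers in a functional assay for inhibition of sodium/hydrogen exchanger (Oryctolagus cuniculus); on this read-out lower numbers stand for stronger inhibition and higher numbers for weaker inhibition. Compound 1 `Cc1cc(Sc2cccc(Cl)c2)c(S(C)(=O)=O)cc1C(=O)N=C(N)N` gives 37 nM. Compound 2 `CCOc1cc(C)c(C(=O)N=C(N)N)cc1S(C)(=O)=O` gives 19 nM. Compound 2 stands lowest of the two, but its nearest neighbour compound 1 sits within the scatter of it, so no order between the two can be read; the step of a 1.9-fold lower number from compound 1 to compound 2 (0.29 log units; within the scatter), which exchanged (3-chlorophenyl)sulfanyl for ethoxy, stayed within the scatter.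

Compound 3 `Cc1cc(Nc2cccc(Cl)c2)c(S(C)(=O)=O)cc1C(=O)N=C(N)N` is not yet measured in this assay . It differs from compound 2 in one place: (3-chlorophenyl)amino in place of ethoxy on an aromatic carbon. Among the measured compounds shown here, the change largely reverses the one measured step, putting a (3-chlorophenyl) group back on the same aromatic carbon, now with an amino link in place of the sulfanyl link. For the measured compounds named here, the only step that bears on it, a 1.9-fold lower number from compound 1 to compound 2 (0.29 log units; within the scatter), was within the scatter, so for compound 3 in this assay no step beyond the scatter is expected in either direction; the expected step of a 1.6-fold higher number from compound 2 to compound 3 (0.20 log units; within the scatter) is small. Compound 3 is thus estimated at 30 nM, with a range of 10 nM to 90 nM.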

Compound 3, half-maximal inhibitory concentration: 33 nM
For compound 3 the middle estimate is 1.1-fold (0.04 log units) below the measured one; measured number inside the range.
By their numbers in this assay, from the lowest: compounds 2, 3 and 1 (each within the scatter of the next).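

In this assay, the aromatic carbon ortho to a methylsulfonyl group has now taken ethoxy, (3-chlorophenyl)sulfanyl and (3-chlorophenyl)amino, and the exchange of ethoxy for (3-chlorophenyl)amino gives a 1.7-fold higher number from compound 2 to compound 3 (0.24 log units; within the scatter), so this change also leaves no readable difference. Among the compounds shown here, the new pair isolates the link to the chlorophenyl ring, which the earlier compounds could not do: exchanging the sulfanyl link for the amino link gives a 1.1-fold lower number from compound 1 to compound 3 (0.05 log units; within the scatter), so the two links cannot be told apart on this read-out. All three compounds thus lie within the scatter of one another, no order can be read at this position, and no available data offer an explanation for how closely these groups agree.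

As far as these compounds go, what remains open is whether any group at this carbon moves the number beyond the scatter, for instance a bare hydrogen, a primary amine, a carboxylic acid or a longer alkoxy chain such as butoxy. From the compounds shown here alone, the contribution of the chlorine is also open, and a plain phenylamino group or a benzyl group would bear on the aryl-bearing side of the series.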